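The source may hold more compounds than are shown below. What is called first, only, known or untested is meant among the compounds shown, and "the series" means these compounds.

Measured compounds in a toxicity assay on WI-38 cells (Homo sapiens) for cytotoxicity, read by MTT assay, with a stated time of 48 h; on this read-out higher numbers stand for weaker inhibition and lower numbers for stronger inhibition:
- compound 1 `O=C(/C=C/c1ccc2c(c1)B(O)OC2)c1ccccc1`: 19100 nM
- compound 2 `O=C(/C=C/c1ccc2c(c1)B(O)OC2)c1ccc(Br)cc1`: 36700 nM
- compound 3 `Nc1ccc(C(=O)/C=C/c2ccc3c(c2)B(O)OC3)cc1`: 25400 nM

In this assay compound 3 stands with the second highest of the three numbers, compound 1 being nearest and compound 2 furthest, and every step among them lies within the scatter: a 1.3-fold higher number from compound 1 to compound 3 (0.12 log units; within the scatter), a 1.9-fold higher number from compound 1 to compound 2 (0.28 log units; within the scatter) and a 1.4-fold lower number from compound 2 to compound 3 (0.16 log units; within the scatter).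

Compound 4 `Nc1cccc(C(=O)/C=C/c2ccc3c(c2)B(O)OC3)c1` differs from compound 3 only in the arrangement of the same atoms: 3-aminophenyl in place of 4-aminophenyl on a carbonyl carbon. For the measured compounds named here, no measured step moves a substituent from one aromatic carbon to another; the steps that bear on the question are those that alter the substituent on that phenyl ring, from compound 1 to compound 3 and from compound 2 to compound 3, and both stayed within the scatter, as did the step from compound 1 to compound 2. Since swapping hydrogen, bromo and amino on this ring left the numbers essentially unchanged, no step beyond the scatter is expected in this assay in either direction, which means an expected step of a 1.0-fold lower number from compound 3 to compound 4 (0.01 log units; within the scatter). Compound 4 is therefore estimated at 25000 nM, with a range from 10000 nM to 60000 nM.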

Compound 4, half-maximal inhibitory concentration: 25300 nM
Beside the measured number, compound 4's estimate is 1.0-fold (0.01 log units) below it, and the stated range covers the measured number.
By their numbers in this assay, from the lowest: compounds 1, 4, 3 and 2 (each within the scatter of the next).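

In this assay, for the compounds shown here, the change from 4-aminophenyl to 3-aminophenyl on the carbonyl carbon gives a 1.0-fold lower number from compound 3 to compound 4 (0.00 log units; within the scatter) and is the first step here that changes where a group sits on this phenyl ring rather than which group it is; the two arrangements cannot be told apart in this assay. The other two steps agree, with a 1.3-fold higher number from compound 1 to compound 4 (0.12 log units; within the scatter) for amino in place of hydrogen and a 1.5-fold lower number from compound 2 to compound 4 (0.16 log units; within the scatter) for 3-aminophenyl in place of 4-bromophenyl, so among these four compounds neither the identity of the substituent nor the placement of the amino group moves the number beyond the scatter. No measured evidence is available to explain this flat result.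

The compounds shown leave open whether a carboxylic acid, a methoxy group or a dimethylamino group on this phenyl ring would stay as flat in this assay as hydrogen, bromo and amino do. They also leave open whether the placement of a group other than amino would matter, and whether the same holds when the shared core is changed.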